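Chain extension on the butylthio series, compound 2 to compound 4

This account rests on a few compounds, and the source may have more. Where it says the series, first, only, none or still open, it means among the compounds named here.

Compound 2 `CCCCSc1nsnc1C1CN2CCC[C@H]1C2` gives 0.045 mg/kg in a functional assay on the whole organism for inhibition, with Mus musculus as the target (a higher number here means that more compound is needed for the effect, a lower number that less compound is needed), the lowest of the two numbers in hand. Compound 3 `CCCSc1nsnc1[C@@H]1CN2CCC[C@H]1C2`, which differs from it in chain length and in one drawn configuration, gives 0.17 mg/kg in this assay; the two values are not a single-point step, so only their gap is noted. Compound 1 `CCCCSc1nsnc1[C@H]1CN2CCC[C@H]1C2` reaches only a limit of the assay, > 1 mg/kg in this assay. Among the measured compounds shown here, the step of an at least 22-fold lower number from compound 1 to compound 2 (1.34 log units; beyond the scatter) is the one measured step, and it turns on the fact that one of compounds 1 and 2 is drawn with a defined configuration and the other without, at the place where they differ together with the limit of > 1 mg/kg in this assay, at which 1 of the 3 values shown sits; it says nothing about the thioether chain.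

Compound 4 `CCCCCCSc1nsnc1C1CN2CCC[C@H]1C2` carries the change (ethyl in place of hydrogen on a saturated chain carbon, four bonds along the chain from a sulfur). For the measured compounds named here, no measured step bears directly on this change. The spread between compound 2 and compound 3 is the only hint that chain length matters in this assay. Compound 4 is therefore expected to give 0.12 mg/kg, between 0.025 mg/kg and 0.6 mg/kg, a step of a 2.7-fold higher number from compound 2 to compound 4 (0.43 log units; beyond the scatter).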

Compound 4, dose for half-maximal effect: 0.06 mg/kg
Compound 4: middle estimate off by 2.0-fold (0.30 log units), on the high side, within the range that was stated.
By their numbers in this assay, from the lowest: compounds 2 and 4 (each within the scatter of the next); then compound 3. At a limit, above all of these: compound 1.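

Among the compounds shown here, the step of a 1.3-fold higher number from compound 2 to compound 4 (0.12 log units; within the scatter) in this assay is the first measured single-place step on the thioether chain, since the earlier measured step concerned only a drawn configuration. It shows that ethyl in place of hydrogen on a saturated chain carbon, four bonds along the chain from a sulfur, is accommodated at this position, with the two compounds lying within the scatter of each other. Nothing in hand explains this result.

Going by these compounds, whether this tolerance extends further remains open, for instance to a longer chain such as octyl, or to a chain carrying an amine or a carboxylic acid. Also open, on these data alone, is how the chain change reads in compounds with every stereo element drawn, as compound 2 and compound 4 both carry one undefined saturated ring carbon.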